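Changing the Ring on the Carbonyl Carbon

The compounds below may be only part of what the source reports. "The series", "measured", "known", "first", "only" and "open" are said of these compounds alone.

Compound 1 `COc1ccc(-c2cc3ccccc3nc2/C=C/C(=O)c2ccc(F)cc2)cc1`: 8320 nM
Compound 2 `COc1ccc(C(=O)/C=C/c2nc3ccccc3cc2-c2ccc(OC)cc2)cc1`: 8500 nM
Compound 3 `COc1ccc(-c2cc3ccccc3nc2/C=C/C(=O)c2ccccn2)cc1`: 6140 nM

Three compounds that share a core and differ only in the ring attached to the carbonyl carbon have been tested in a functional assay on A549 cells (Homo sapiens) for antiproliferative activity, read by XTT assay, with a stated time of 72 h; a higher number here means a weaker inhibitor, a lower number a stronger inhibitor. Compound 3 has the smallest of the three numbers, but this means little: the steps of a 1.4-fold lower number from compound 1 to compound 3 (0.13 log units; within the scatter) and a 1.4-fold lower number from compound 2 to compound 3 (0.14 log units; within the scatter) both fall inside the scatter, as does a 1.0-fold higher number from compound 1 to compound 2 (0.01 log units; within the scatter). In practice the three compounds stand together.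

Compound 4 `COc1ccc(-c2cc3ccccc3nc2/C=C/C(=O)c2cnc(N)nc2C)cc1` is the next step from compound 3, and the change is again at the carbonyl carbon: 2-amino-4-methylpyrimidin-5-yl in place of pyridin-2-yl on a carbonyl carbon. The two measured steps that bear on this are the ones that swapped the ring on the carbonyl carbon, namely a 1.4-fold lower number from compound 1 to compound 3 (0.13 log units; within the scatter) and a 1.4-fold lower number from compound 2 to compound 3 (0.14 log units; within the scatter); neither moved the number beyond the scatter, even though the rings exchanged differed in a ring nitrogen and in a substituent. On that basis the expected step from compound 3 to compound 4 in this assay is none beyond the scatter, a 1.1-fold higher number from compound 3 to compound 4 (0.02 log units; within the scatter). Compound 4 is therefore estimated at 6500 nM, with a likely range from 3000 nM to 14000 nM.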

Compound 4, half-maximal inhibitory concentration: > 10000 nM
Compound 4 was reported as a limit (the forecaster's own chance of this, stated with the estimate: 10%); at least 1.5-fold (0.18 log units) between middle value and limit.
By their numbers in this assay, from the lowest: compounds 3, 1 and 2 (each within the scatter of the next). At a limit, above all of these: compound 4.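

In this assay, compound 4 is the only compound shown whose result at the carbonyl carbon is a limit and not a number: the limit of > 10000 nM in this assay, at which 1 of the 4 values shown sits.

The earlier rings on this carbon, pyridin-2-yl, 4-fluorophenyl and 4-methoxyphenyl, all gave numbers that stood together, whereas 2-amino-4-methylpyrimidin-5-yl takes the series to the limit of the assay for the first time among these compounds. What can be read are floors, not full steps: an at least 1.6-fold higher number from compound 3 to compound 4 (0.21 log units; that floor lies within the scatter), an at least 1.1-fold higher number from compound 2 to compound 4 (0.07 log units; that floor lies within the scatter) and an at least 1.2-fold higher number from compound 1 to compound 4 (0.07 log units; that floor lies within the scatter). Each floor lies within the scatter, so this change is not yet shown to differ from the earlier ring swaps, and the true size of all three steps stays unknown.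

The compounds shown also do not separate the amine, the methyl and the ring nitrogens of the entering group, as all of them arrive together in compound 4. From the compounds shown here alone, it remains open whether a plain pyrimidin-5-yl ring, or a pyridin-3-yl ring carrying only an amine, would stand with compound 3 or with compound 4.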